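Swapping chloro for fluoro on a pyrazine hydrazone scaffold

This account rests on a few compounds, and the source may have more. Where it says the series, first, only, none or still open, it means among the compounds named here.

Measured so far in an ADME assay on J774 cells (Mus musculus) for cytotoxicity, read by MTT assay, with a stated time of 48 h, tested at 50 ug/mL; a higher number here means a weaker effect of the compound at the concentration tested, a lower number a stronger effect:
Compound 1 `O=C(N/N=C/c1cccc(Cl)c1)c1cnccn1` gives 100%.
Compound 2 `O=C(N/N=C/c1ccc(Cl)cc1)c1cnccn1` gives 83%.
Compound 3 `O=C(N/N=C/c1cccc(F)c1)c1cnccn1` gives 49%.

Compound 1 and compound 2 share the same atoms joined differently; how their two cores differ is not broken down here. Among the measured compounds shown here, the one change that has been measured is fluoro in place of chloro on an aromatic carbon, and it produced a number 51 percentage points lower from compound 1 to compound 3 (beyond the scatter). Compound 4 `O=C(N/N=C/c1ccc(F)cc1)c1cnccn1` is not yet measured; it differs from compound 2 by fluoro in place of chloro on an aromatic carbon. This is the same kind of change, though the place differs: in compound 3 the fluoro sits meta to a large group, in compound 4 para to a large group. For compound 4 a step of a number 43 percentage points lower from compound 2 to compound 4 (beyond the scatter) is expected, resting on the measured a number 51 percentage points lower from compound 1 to compound 3 (beyond the scatter) applied to compound 2. Compound 4 is therefore estimated at 40%, plausibly between 15% and 75%.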

Compound 4, a percentage reported as activity, at one concentration (the size of the read-out at that concentration, not a potency): 78%
For compound 4 the middle estimate is 38 percentage points below the measured one, and the stated range ends below it.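

In this assay, putting fluoro in place of chloro gave a number 5 percentage points lower from compound 2 to compound 4 (within the scatter). Set beside the earlier step, the same swap did not carry over from one core to the other: the same change on two cores in this assay, a number 51 percentage points lower (beyond the scatter) from compound 1 to compound 3 and a number 5 percentage points lower (within the scatter) from compound 2 to compound 4, 46 percentage points apart, beyond the scatter of two such steps. So in this series, a step measured on one core is a poor guide to the same swap on the other, although two pairs cannot show why the steps differ or how the swap would behave on a further core.

The compounds shown carry only chloro or fluoro on the carbon-only aromatic ring. From the compounds shown here alone, what a methoxy group, an amine or a carboxylic acid would do there remains open.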